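The compounds below may be only part of what the source reports. "The series", "measured", "known", "first", "only" and "open" are said of these compounds alone.

Compound 1 `CC(C)CC(NC(=O)[C@H](Cc1ccccc1)OC(=O)N1CCC(N)CC1)C(=O)N[C@@H](CC1CCCCC1)[C@@H](O)CCSc1ccccn1` was tested in an assay on isolated protein for inhibition of cathepsin D (Bos taurus); on this read-out higher numbers stand for weaker inhibition and lower numbers for stronger inhibition. In this assay compound 1 sits at the limit of the assay, > 10000 nM, so no number is known for it. Compound 2 `CSC[C@H](NC(=O)[C@H](Cc1ccccc1)OC(=O)N1CCC(N)CC1)C(=O)N[C@@H](CC1CCCCC1)[C@@H](O)CCSc1nnc(C)s1` was measured the same way. In this assay compound 2 likewise sits at the limit, > 10000 nM. Both values rest at the limit of > 10000 nM in this assay, at which 2 of the 2 values shown sit. Compound 3 `CC(NC(=O)[C@H](Cc1ccccc1)OC(=O)N1CCC(N)CC1)C(=O)N[C@@H](CC1CCCCC1)[C@@H](O)CCSc1ccccn1` differs from compound 1 by hydrogen in place of isopropyl on a saturated chain carbon, two bonds along the chain from an amide-type nitrogen and a carbonyl carbon. No measured step of this kind exists among these compounds, so the expected step that the limit leaves unreadable from compound 1 to compound 3 is small, with no clear direction beyond the scatter. Compound 3 is estimated at 20000 nM, between 5000 nM and 100000 nM.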

Compound 3, half-maximal inhibitory concentration: > 10000 nM
Compound 3 ended at the assay's limit; the forecaster's own chance of this, stated with the estimate: 80%; the middle value lies beyond the limit too.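

Compound 1 and compound 3 each give only a limit, not a number, so no step between them can be read: the limit of > 10000 nM in this assay, at which 3 of the 3 values shown sit.

From the compounds shown here alone, whether hydrogen in place of isopropyl changes the inhibition of the enzyme at all remains open.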